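The source may hold more compounds than are shown below. What is called first, only, known or untested is meant among the compounds shown, and "the series" means these compounds.

Measured compounds in a functional assay on SW 1116 cells (Homo sapiens) for cytotoxicity, read by MTT assay, with a stated time of 48 h; on this read-out higher numbers stand for weaker inhibition and lower numbers for stronger inhibition:
compound 1 `NNC(=O)CSc1nnc(-c2ccncc2)o1` gives 3260 nM
compound 2 `O=C(CSc1nnc(-c2ccncc2)o1)N/N=C/c1ccc(Cl)cc1` gives 17000 nM
compound 3 `O=C(CSc1nnc(-c2ccncc2)o1)N/N=C/c1ccc(O)cc1` gives 12200 nM

On these three numbers compound 1 stands lowest: compound 3 gives a higher number than compound 1, and compound 2 a higher number still, both gaps beyond the scatter. The unmeasured compound 4 `O=C(CSc1nnc(-c2ccncc2)o1)N/N=C/c1cccs1` differs from compound 1 by a group of 7 heavy atoms (5 carbon, 1 nitrogen, 1 sulfur; one five-membered aromatic ring with 1 hetero atom) in place of one nitrogen atom, on an amide-type nitrogen. Within the data shown here, no measured step covers this exact change. Compounds 2 and 3, however, both carry a larger group on the same amide-type nitrogen where compound 1 carries amino, and both give higher numbers than compound 1 in this assay. Among the measured compounds shown here, the one step between them, a 1.4-fold lower number from compound 2 to compound 3 (0.14 log units; within the scatter), stays within the scatter, so the exchange of a hydroxy for a chloro on an aromatic carbon did not move the number. Compound 4 is therefore expected to give a higher number than compound 1, in the region of compounds 2 and 3, an estimated step of a 3.7-fold higher number from compound 1 to compound 4 (0.57 log units; beyond the scatter). For compound 4 the estimate is 12000 nM, with a range from 5000 nM to 30000 nM.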

Compound 4, half-maximal inhibitory concentration: 24900 nM
Estimate against measurement, compound 4: 2.1-fold (0.32 log units) below; the measured number falls inside the stated range.
By their numbers in this assay, from the lowest: compound 1; then compounds 3, 2 and 4 (each within the scatter of the next, the first and the last beyond it).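

In this assay, the step on the amide-type nitrogen, a 7.6-fold higher number from compound 1 to compound 4 (0.88 log units; beyond the scatter), shows that a group carrying a five-membered aromatic ring also gives a higher number than amino, as the groups with 4-chlorophenyl and 4-hydroxyphenyl did. At the carbon with a double bond to nitrogen, thiophen-2-yl in place of 4-hydroxyphenyl gives a 2.0-fold higher number from compound 3 to compound 4 (0.31 log units; beyond the scatter), just beyond the scatter, whereas thiophen-2-yl in place of 4-chlorophenyl gives a 1.5-fold higher number from compound 2 to compound 4 (0.17 log units; within the scatter), within it, so the effect of this ring exchange depends on the comparison compound. Nothing at hand bears on the cause of these steps.

As far as these compounds go, what a longer alkyl chain or a carboxylic acid on the carbon with a double bond to nitrogen would give remains open. Also open, from the compounds shown here alone, is whether any group on the amide-type nitrogen, such as a methyl group, would match or go lower than amino.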